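Shifting methoxy groups on a nitro-bearing amide scaffold

The source may hold more compounds than are shown below. What is called first, only, known or untested is meant among the compounds shown, and "the series" means these compounds.

Compound 1, `Cc1ccc(NC(=O)c2cccc(C(F)(F)F)c2)cc1NC(=O)c1cnc(Nc2ccc(C)c([N+](=O)[O-])c2)nc1N(C)C`, gives > 10000 nM in a functional assay on K562 cells (Homo sapiens) for antiproliferative activity, read by CellTiter-Glo and CCK-8 assay, with a stated time of 72 h; a higher number here means a weaker inhibitor of growth, a lower number a stronger inhibitor of growth; this is a limit.
Compound 2, `CNc1nc(Nc2ccc(C)c(N)c2)ncc1C(=O)Nc1cc(NC(=O)c2cccc(C(F)(F)F)c2)ccc1C`, gives 14 nM in this assay.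
Compound 3, `CNc1nc(Nc2ccc(C)c([N+](=O)[O-])c2)ncc1C(=O)Nc1cc(NC(=O)c2ccccc2OC)ccc1C`, gives > 10000 nM in this assay; this is a limit.

Compound 3 stands at the limit of > 10000 nM in this assay, at which 2 of the 3 values shown sit, and compound 2 is the only one of the three with a measured number. Compound 4, `CNc1nc(Nc2ccc(C)c([N+](=O)[O-])c2)ncc1C(=O)Nc1cc(NC(=O)c2cc(OC)cc(OC)c2)ccc1C`, keeps the rest of compound 3 and changes only the outer amide: 3,5-dimethoxyphenyl in place of 2-methoxyphenyl on a carbonyl carbon. Among the compounds with values here, no step between two measured compounds isolates this change. Both nitro-bearing compounds stop at the limit, so the change from compound 3 to compound 4 is expected to give no step beyond the scatter. Compound 4 is therefore estimated at 20000 nM (range 5000 nM to 100000 nM), an expected step that the limit leaves unreadable from compound 3 to compound 4.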

Compound 4, concentration for 50% growth inhibition: 1070 nM
Compound 4: middle estimate off by 19-fold (1.27 log units), on the high side, outside the stated range (below it).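

The outer amide matters even with the nitro group present: 3,5-dimethoxyphenyl in place of 2-methoxyphenyl on a carbonyl carbon gives an at least 9.3-fold lower number from compound 3 to compound 4 (0.97 log units; beyond the scatter) in this assay. Within the data shown here, a nitro-bearing compound on this scaffold can therefore leave the limit, which the earlier compounds did not show. Compound 3 has a limit and not a number, so this step is only a minimum: the limit of > 10000 nM in this assay, at which 2 of the 4 values shown sit.

As far as these compounds go, it remains open whether the methoxy oxygens themselves matter. A 3,5-dimethylphenyl on the same carbonyl carbon would test that.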